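Removing the methoxy group from a thiosemicarbazide-bearing pyrazoline

The source may report more compounds than this note shows. Statements on the series, on what has been measured and on what is new or still open speak of the compounds shown alone.

This account concerns three compounds measured in an in vitro assay on cells for inhibition of Amine oxidase [flavin-containing] A (Homo sapiens), read by Amplex Red, with a stated time of 15 min, tested at 100 uM (a higher number here means more inhibition at the concentration tested (going by the name of the read-out), a lower number less inhibition), and one that has not yet been tested. Compound 1 `NC(=S)N1CCC(c2cccs2)=N1` is reported in this assay as "not active" (no number reported). Compound 2 `CNC(=S)N1CC(C)C(c2ccc(OC)cc2)=N1` is reported in this assay as "not active" (no number reported), so no single number is available for it; it shares this outcome with one further entry. Compound 3 `COc1ccc(C2=NN(C(N)=S)CC2C)cc1` gives 40% in this assay.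

The step of interest leads from compound 2 to compound 4 `CNC(=S)N1CC(C)C(c2ccccc2)=N1`, which has not yet been measured in this assay. The change is hydrogen in place of methoxy on an aromatic carbon. Among the measured compounds shown here, no step between measured compounds is available for this change, so its size can only be expected. Compound 2 reported no measurable inhibition, and the change removes only a small group, so the step in this assay is expected to stay within the scatter, with compound 4 remaining weak. Compound 4 is therefore estimated at 12%, within a range from 0% to 35%.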

Compound 4, a percentage reported as inhibition, at one concentration (the size of the read-out at that concentration, not a potency): "not active" (no number reported)
Nothing numeric was reported for compound 4; there is nothing to compare the estimate with.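

In this assay neither compound 2 nor compound 4 has a single number, so the step between them cannot be read. The compounds shown leave open whether methoxy or hydrogen at this place changes inhibition at all. No further evidence bears on this result.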